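The compounds below may be only part of what the source reports. "The series", "measured", "known", "first", "only" and "open" are said of these compounds alone.

Measured so far in an assay on isolated protein for inhibition of sphingosine kinase 1 (Homo sapiens), read by mobility shift assay; on this read-out higher numbers stand for weaker inhibition and lower numbers for stronger inhibition:
compound 1, `CCCCCCCCc1ccc(NC(=O)[C@@H](N)[C@@H](C)O)cc1`: 650 nM
compound 2, `CCCCCCCCc1ccc(NC(=O)[C@@H](N)[C@H](C)O)cc1`: 1100 nM

Among the compounds with values here, compound 2 sits within the scatter of compound 1, the only other number in this assay; the step of a 1.7-fold higher number from compound 1 to compound 2 (0.23 log units; within the scatter) rests on (the fact that compounds 1 and 2 differ only in the configuration as drawn). Compound 3, `CCCCCCCCc1ccc(NC[C@H]2NCC[C@@H]2O)cc1`, carries (3-hydroxypyrrolidin-2-yl)methyl in place of (1-amino-2-hydroxypropyl)carbonyl on a nitrogen on an aromatic ring. Within the data shown here, no measured step touches this change: the one step known is a configurational swap, so it says nothing about exchanging an amide for a ring-bearing amine. For compound 3 the expected step of a 1.4-fold higher number from compound 2 to compound 3 (0.13 log units; within the scatter) is a guess with a wide range, with a weaker number on balance. Compound 3 is therefore estimated at 1500 nM, between 300 nM and 8000 nM.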

Compound 3, half-maximal inhibitory concentration: 740 nM
The estimate for compound 3 lay 2.0-fold (0.31 log units) above the measured number; the measured number falls inside the stated range.
By their numbers in this assay, from the lowest: compounds 1, 3 and 2 (each within the scatter of the next).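

In this assay, (3-hydroxypyrrolidin-2-yl)methyl in place of (1-amino-2-hydroxypropyl)carbonyl on a nitrogen on an aromatic ring gives a 1.5-fold lower number from compound 2 to compound 3 (0.17 log units; within the scatter) and a 1.1-fold higher number from compound 1 to compound 3 (0.06 log units; within the scatter). Unlike the earlier configurational pair, this shows that the carbonyl and the open chain can be exchanged for a five-membered non-aromatic ring in these compounds with no step beyond the scatter. Nothing measured here explains this result.

Open, going by these compounds, is how a four-membered azetidine ring or a six-membered piperidine ring would read in place of the entering ring. On these data alone, the role of the configuration at its two defined stereocentres is also open.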